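From compound 3 to compound 4: one added chloro

The source may hold more compounds than are shown below. What is called first, only, known or untested is meant among the compounds shown, and "the series" means these compounds.

The results from a functional assay on KB cells (Homo sapiens) for inhibition, read by MTT assay, with a stated time of 24 h, tested at 0.1 ug/mL (on this read-out lower numbers stand for less inhibition of growth and higher numbers for more inhibition of growth at the one concentration tested), are sparse. In this assay, compound 1 `O=C(CCCCC1CCSS1)Nc1ccc(Br)cn1` is reported as "not active" (no number reported), and compound 2 `O=C(CCCCC(S)CCS)Nc1ccc(Br)cn1` as "not active" (no number reported), so neither of them comes with a number. Compound 3 `CC(=O)SCCC(CCCCC(=O)Nc1ccccc1)SC(C)=O` gives 7.24%, the only figure available, which leaves it with no other number to be ranked against. Among the compounds with values here, no two of these three compounds differ in just one place, so the data contain no measured step to serve as a guide.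

Compound 4 `CC(=O)SCCC(CCCCC(=O)Nc1cccc(Cl)c1)SC(C)=O` is compound 3 with a single alteration on its aromatic ring: chloro in place of hydrogen on an aromatic carbon. Chloro takes the place of hydrogen on an aromatic carbon, meta to a large group, which turns the phenyl into a 3-chlorophenyl.

With nothing measured to suggest a large shift, the expectation is a slight rise in this assay that stays within the usual scatter of the test. The expected change is a number 2.8 percentage points higher from compound 3 to compound 4 (within the scatter). Within the data shown here, this expectation is anchored on compound 3 and its 7.24%, the only number there is. The estimated value for compound 4 is 10%, with an expected range from 2% to 22%.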

Compound 4, percent growth inhibition at one concentration: 5.72%
Compound 4: middle estimate off by 4.3 percentage points, on the high side, within the range that was stated.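

Within the data shown here, the chloro step is the first single change in this set that can be read, and it sets a 3-chlorophenyl in place of the phenyl. In this assay it comes to a number 1.5 percentage points lower from compound 3 to compound 4 (within the scatter), so at this one position, at the one concentration tested, adding a chloro has no effect that can be told apart from the ordinary spread of repeat measurements. Nothing available here bears on why the read-out behaves this way, so the result stands as an observation without an explanation.

As far as these compounds go, one substituent at one place says little about the rest of the ring, so it stays open whether a chloro elsewhere on the phenyl, or an amine, a carboxylic acid or a methoxy group at this same place, would move the figure beyond that spread. Also open, from the compounds shown here alone, is what a longer chain between the amide carbonyl and the sulfur-bearing carbon would do, and whether compound 3 and compound 4 would still read alike at other concentrations.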